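A few compounds are considered here, and "the series" means these few. Any claim that something is new, unique, unknown or untested is made for them only; others in the source may bear on it.

Measured compounds:
Compound 2 `CCCSc1nc(N/N=C/c2ccc(N(C)C)cc2)c2nnn(Cc3ccccc3)c2n1` gives 12200 nM in a functional assay on MCF7 cells (Homo sapiens) for antiproliferative activity, read by MTT assay, with a stated time of 72 h; on this read-out higher numbers stand for weaker inhibition and lower numbers for stronger inhibition.
Compound 1 `CCCSc1nc(N/N=C(\C)c2ccccc2O)c2nnn(Cc3ccco3)c2n1` gives 29000 nM in this assay.
Compound 3 `C#CCSc1nc(N/N=C/c2ccc(N(C)C)cc2)c2nnn(Cc3ccccc3)c2n1` is reported only as a limit of this assay, > 64000 nM.

Compound 2 stands lowest of the two numbers; compound 1 sits higher, and the gap between the two lies beyond the scatter. Among the measured compounds shown here, the only step measured between compounds that differ in one place is an at least 5.2-fold higher number from compound 2 to compound 3 (0.71 log units; beyond the scatter), where ethynyl replaces ethyl on a saturated chain carbon bound to a sulfur; since compound 3 is reported only at the limit (the limit of > 64000 nM in this assay, at which 1 of the 3 values shown sits), that step is known only as a lower bound.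

Compound 4 `CCCSc1nc(N/N=C/c2cccc(Cl)c2)c2nnn(Cc3ccccc3)c2n1` has not been measured. It differs from compound 2 by 3-chlorophenyl in place of 4-(dimethylamino)phenyl on a carbon with a double bond to nitrogen. For the measured compounds named here, no measured step touches the group on the carbon with a double bond to nitrogen, so nothing among the measured compounds speaks to this change, and no step beyond the scatter is expected. Compound 4 is therefore estimated at 15000 nM, within 5000 nM to 45000 nM, which means an expected step of a 1.2-fold higher number from compound 2 to compound 4 (0.09 log units; within the scatter).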

Compound 4, half-maximal inhibitory concentration: > 64000 nM
Compound 4 gave a limit, no number; the forecaster's own chance of this, stated with the estimate: 10%; at least 4.2-fold (0.63 log units) between middle value and limit.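

In this assay, the group on a carbon with a double bond to nitrogen proves to matter: replacing 4-(dimethylamino)phenyl with 3-chlorophenyl gives an at least 5.2-fold higher number from compound 2 to compound 4 (0.71 log units; beyond the scatter). Compound 2 therefore gives way to a limit through a change at either of two places, the chain bound to sulfur in compound 3 and this group in compound 4. Compound 4 is reported only as a limit, so this step is a lower bound and its full size stays unknown: the limit of > 64000 nM in this assay, at which 2 of the 4 values shown sit.

The compounds shown cannot separate the loss of the dimethylamino group from the arrival of the chlorine, as this one change does both. Also open, going by these compounds, is how a plain phenyl or a methoxyphenyl would read at this place.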